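Replacing the Acetoxy Group of Compound 3

The compounds below may be only part of what the source reports. "The series", "measured", "known", "first", "only" and "open" are said of these compounds alone.

- compound 1 `NS(=O)(=O)c1ccc(SCCO)c(F)c1` gives 9.76
- compound 2 `NS(=O)(=O)c1ccc(SCCO)c(C(=O)O)c1` gives 10.5
- compound 3 `CC(=O)OCCS(=O)(=O)c1ccc(S(N)(=O)=O)s1` gives 8.65

In a physicochemical assay for acid dissociation, compound 3 gives 8.65 as the lowest of the three numbers, with compound 1 nearest and compound 2 furthest. Compound 4 `CC(C)CNCCCS(=O)(=O)c1ccc(S(N)(=O)=O)s1` differs from compound 3 by (isobutylamino)methyl in place of acetoxy on a saturated chain carbon, two bonds along the chain from a sulfonyl sulfur with (isobutylamino)methyl in place of acetoxy on a saturated chain carbon, two bonds along the chain from a sulfonyl sulfur. Going by the values given here, the only measured step is a number 0.74 log units higher from compound 1 to compound 2 (beyond the scatter) with carboxy in place of fluoro on an aromatic carbon. That is a different swap at a different kind of place, so it bears only loosely here. The expected change is small, a number 0.15 log units higher from compound 3 to compound 4 (within the scatter) and not beyond the scatter. For compound 4 the estimated value is 8.8 with an expected range of 8.2 to 9.4 on this scale.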

Compound 4, acid dissociation constant: 9.3
Beside the measured number, compound 4's estimate is 0.50 log units below it; the measured number falls inside the stated range.
By their numbers in this assay, from the lowest: compound 3; then compound 4; then compound 1; then compound 2.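

In this assay the swap of acetoxy for (isobutylamino)methyl gives a number 0.65 log units higher from compound 3 to compound 4 (beyond the scatter) on this saturated chain carbon. Going by these compounds alone, the only earlier step was on an aromatic carbon, so this is the first sign that a change on the chain, two bonds along from a sulfonyl sulfur, can also move the number beyond the scatter. Nothing shown gives a reason for this shift.

On these data alone, the amine and the added carbons arrive together in one swap, and which of them matters stays open. A plain alkyl chain or a carboxylic acid at this place would bear on that question.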